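Phenoxy ether chain series: cytotoxicity working notes

The compounds below may be only part of what the source reports. "The series", "measured", "known", "first", "only" and "open" are said of these compounds alone.

Values in an ADME assay on L6 cells (Rattus norvegicus) for cytotoxicity, read by resazurin assay, with a stated time of 70 h; on this read-out higher numbers stand for weaker inhibition and lower numbers for stronger inhibition
- compound 1 `CC(C)NC(=N)c1ccc2cc(-c3ccc(OCCCCOc4ccccc4)cc3)oc2c1` at 15900 nM
- compound 2 `CC(C)NC(=N)c1ccc2cc(-c3ccc(OCCCCCOc4ccccc4)cc3)oc2c1` at 10700 nM
- compound 3 `CC(C)NC(=N)c1ccc2cc(-c3ccc(OCCCCCCOc4ccccc4)cc3)oc2c1` not yet measured

Compound 2 stands at 10700 nM with only compound 1 for comparison, and the measured step, a 1.5-fold lower number from compound 1 to compound 2 (0.17 log units; within the scatter) sets no order between the two. The move to compound 3 is phenoxymethyl in place of phenoxy on a saturated chain carbon, five bonds along the chain from an oxygen on an aromatic ring and reads as phenoxymethyl in place of phenoxy on a saturated chain carbon, five bonds along the chain from an oxygen on an aromatic ring. Going by the values given here, the one measured step that bears on it is the same exchange four bonds along, and it stayed small. One step gives no trend, so nothing beyond the scatter is expected in this assay and no direction can be firmly called. The estimated move is a 1.1-fold lower number from compound 2 to compound 3 (0.05 log units; within the scatter) and no more than that is expected. Compound 3 is estimated at 9500 nM with an expected range of 4500 nM to 19000 nM for now.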

Compound 3, half-maximal inhibitory concentration: 4900 nM
The estimate for compound 3 lay 1.9-fold (0.29 log units) above the measured number, within the range that was stated.
By their numbers in this assay, from the lowest: compound 3; then compounds 2 and 1 (each within the scatter of the next).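

In this assay, this exchange now gives a step that clears the scatter: a 2.2-fold lower number from compound 2 to compound 3 (0.34 log units; beyond the scatter) at five bonds along the chain, whereas a 1.5-fold lower number from compound 1 to compound 2 (0.17 log units; within the scatter) at four bonds along did not. With 2-phenoxyethyl in place of phenoxy at the four-bond position, the change is a 3.2-fold lower number from compound 1 to compound 3 (0.51 log units; beyond the scatter) and so compound 3 stands apart from both compounds with shorter chains, while those two remain within the scatter of each other. No measurement given here accounts for this change.

On these data alone, with only these three compounds, it remains open whether a longer chain would bring the number lower still or whether the values would level off. As far as these compounds go, it is also open whether an amine in place of the phenoxy would follow the same course on the shared core.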